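A few compounds are considered here, and "the series" means these few. Any claim that something is new, unique, unknown or untested is made for them only; others in the source may bear on it.

The compounds share one core, varied at the hydrocarbon tail and at the amino acid arm. In an ADME assay on L1210 cells (Mus musculus) for cytotoxicity, with a stated time of 48 h (on this read-out lower numbers stand for stronger inhibition and higher numbers for weaker inhibition), compound 1 `CC1=CCC[C@](C)(CC/C(C)=C/CC2=C(O)C(=O)C=C(N[C@@H](C(=O)O)[C@@H](C)O)C2=O)[C@@H]1C` gives only a limit, > 10 ug/mL, not a number. Compound 3 `C=C1[C@H](C)CCC[C@]1(C)CC/C(C)=C/CC1=C(O)C(=O)C=C(N[C@@H](C(=O)O)[C@@H](C)O)C1=O` likewise gives only a limit in this assay, > 10 ug/mL. Compound 2 `C=C1[C@H](C)CCC[C@]1(C)CC/C(C)=C/CC1=C(O)C(=O)C=C(N[C@@H](C(=O)O)[C@H](C)O)C1=O` gives 4.6 ug/mL in this assay. The step that the two limits leave unreadable from compound 1 to compound 3 cannot be read because of the limit of > 10 ug/mL in this assay, at which 2 of the 3 values shown sit. The step of an at least 2.1-fold higher number from compound 2 to compound 3 (0.33 log units; beyond the scatter) rests on (the fact that compounds 2 and 3 differ only in the configuration as drawn). Compound 1 thus stands at the limit of this assay, and one further value is a limit too.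

Compound 4 `CC1=CCC[C@](C)(CC/C(C)=C/CC2=C(O)C(=O)C=C(NCC(=O)O)C2=O)[C@@H]1C` differs from compound 1 by hydrogen in place of 1-hydroxyethyl on a saturated chain carbon bound to an amine nitrogen and a carbonyl carbon. Neither measured step touches this change: one exchanges a six-membered non-aromatic ring of carbon only for another, the other alters configuration alone. Among the compounds with values here, no measured step bears on the step from compound 1 to compound 4. Compound 4 is therefore expected to remain near the limit, estimated at 10 ug/mL with a range from 4 ug/mL to 25 ug/mL. The expected step of a number no higher from compound 1 to compound 4 (the limit leaves the size open) is estimated as small.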

Compound 4, half-maximal inhibitory concentration: 3.5 ug/mL
Compound 4: middle estimate off by 2.9-fold (0.46 log units), on the high side, outside the stated range (below it).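

Hydrogen in place of 1-hydroxyethyl, on a saturated chain carbon bound to an amine nitrogen and a carbonyl carbon, gives an at least 2.8-fold lower number from compound 1 to compound 4 (0.45 log units; beyond the scatter) in this assay, and this is the first measured change that removes a group there instead of altering configuration alone. With the hydrocarbon tail of compound 1 kept, the 1-hydroxyethyl group is thus not needed for a readable value, and its loss goes with stronger inhibition. The true size of this step stays open because compound 1 carries only a limit: the limit of > 10 ug/mL in this assay, at which 2 of the 4 values shown sit.

As far as these compounds go, whether methyl, a longer chain or an aminomethyl group in that place would read like compound 1 or like compound 4 remains open. From the compounds shown here alone, it is also open whether the same change would carry over to the hydrocarbon tail of compound 3.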